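This account rests on a few compounds, and the source may have more. Where it says the series, first, only, none or still open, it means among the compounds named here.

Within the data shown here, in an ADME assay on MT4 cells (Homo sapiens) for cytotoxicity, read by MTT assay (a lower number here means that less compound is tolerated, a higher number that more compound is tolerated), three related compounds have numbers so far. Compound 1 `Cc1ccc(NC(=O)CSc2nncnc2-c2cccc3ccccc23)c(Br)c1` gives 166000 nM, compound 2 `O=C(CSc1nncnc1-c1ccccc1Cl)Nc1ccccc1Br` gives 73000 nM, and compound 3 `CC(=O)c1ccc(NC(=O)CSc2nncnc2-c2ccccc2Cl)c(Br)c1` gives 34000 nM. Compound 3 therefore holds the lowest number of the three, and its gap to each of the others lies beyond the usual scatter.

Compound 4 `COC(=O)c1ccc(NC(=O)CSc2nncnc2-c2ccccc2Cl)c(Br)c1` has not yet been measured. It differs from compound 3 in one place: methoxy in place of methyl on a carbonyl carbon. Put simply, this is methoxy in place of methyl on a carbonyl carbon, which turns acetyl into methoxycarbonyl.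

Among the measured compounds shown here, only one measured step bears on this change: a 2.1-fold lower number from compound 2 to compound 3 (0.33 log units; beyond the scatter). There, acetyl in place of hydrogen on an aromatic carbon gave a modest step, only just beyond the scatter. The new change does not add or remove that group but alters its outer end, so a step of this size is a rough upper guide rather than a direct precedent. For the measured compounds named here, no measured pair shows methoxy replacing methyl, so the direction remains open, and no step beyond the scatter is expected in this assay. The estimated step is a 1.1-fold higher number from compound 3 to compound 4 (0.02 log units; within the scatter). For compound 4 the estimate is 36000 nM, with an expected range from 17000 nM to 75000 nM.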

Compound 4, half-maximal cytotoxic concentration: 59000 nM
Compound 4: middle estimate off by 1.6-fold (0.21 log units), on the low side; the measured number falls inside the stated range.
By their numbers in this assay, from the lowest: compounds 3, 4 and 2 (each within the scatter of the next, the first and the last beyond it); then compound 1.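

In this assay, putting methoxy in place of methyl on a carbonyl carbon, which turns acetyl into methoxycarbonyl, gives a 1.7-fold higher number from compound 3 to compound 4 (0.24 log units; within the scatter) and so cannot be told apart from ordinary repeat-to-repeat variation. Measured against the compound with hydrogen on that aromatic carbon, methoxycarbonyl gives a 1.2-fold lower number from compound 2 to compound 4 (0.09 log units; within the scatter) and also stays within the scatter, whereas acetyl gave a 2.1-fold lower number from compound 2 to compound 3 (0.33 log units; beyond the scatter) and lay beyond it. The earlier step therefore does not carry over to every carbonyl-bearing group at this place, although the acetyl and methoxycarbonyl compounds cannot themselves be separated, and no measurement on hand offers an explanation for these results.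

On these data alone, it remains open whether a carboxylic acid or an amide on the same aromatic carbon would also stay within the scatter of compound 2, and whether ethoxy or a longer chain in place of methoxy would shift the number. As far as these compounds go, it is also open whether the change from acetyl to methoxycarbonyl would give a similar result on the core of compound 1.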